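The source may hold more compounds than are shown below. What is called first, only, known or untested is meant among the compounds shown, and "the series" means these compounds.

Of the compounds shown here, two have been measured in an assay on THP-1 cells for antagonist activity at P2X purinoceptor 7 (Homo sapiens), read by ELISA, with a stated time of 30 min; a lower number here means a stronger inhibitor, a higher number a weaker inhibitor. Compound 1 `CNC(=O)c1cccc(S(=O)(=O)Oc2ccc(-c3cncn3C3CCN(C(=O)c4ccc(Cl)c(C(F)(F)F)c4)CC3)cc2)c1` gives 1.76 nM, and compound 2 `CNC(=O)c1cccc(S(=O)(=O)Oc2ccc(-c3cncn3C3CCN(C(=O)c4ccc([N+](=O)[O-])cc4)CC3)cc2)c1` gives 26 nM. Going by the values given here, the single step available, a 15-fold higher number from compound 1 to compound 2 (1.17 log units; beyond the scatter), shows that the group on the carbonyl carbon of the shared core can shift the number strongly. Compound 2 thus holds the highest number of the two measured compounds, and its nearest neighbour, compound 1, lies well below it. Compound 3 `CNC(=O)c1cccc(S(=O)(=O)Oc2ccc(-c3cncn3C3CCN(C(=O)c4ccc(N(C)C)cc4)CC3)cc2)c1` differs from compound 2 by dimethylamino in place of nitro on an aromatic carbon. No measured step exchanges this same pair of groups, so the size and direction of the change in this assay cannot be read from any shown pair; the one shown step concerns different groups and was large. The expectation starts from compound 2 at 26 nM and carries a wide range. Compound 3 is expected to give an estimated 30 nM, between 8 nM and 120 nM. The step this expectation implies is a 1.2-fold higher number from compound 2 to compound 3 (0.06 log units; within the scatter).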

Compound 3, half-maximal inhibitory concentration: 22 nM
Estimate against measurement, compound 3: 1.4-fold (0.13 log units) above, and the stated range covers the measured number.
By their numbers in this assay, from the lowest: compound 1; then compounds 3 and 2 (each within the scatter of the next).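

Exchanging nitro for dimethylamino on this aromatic carbon gives a 1.2-fold lower number from compound 2 to compound 3 (0.07 log units; within the scatter) in this assay, so the two groups cannot be told apart at this place, para to a large group. Each of them also stands well away from the 4-chloro-3-(trifluoromethyl)phenyl of compound 1: a 13-fold higher number from compound 1 to compound 3 (1.10 log units; beyond the scatter) is a large step, as is a 15-fold higher number from compound 1 to compound 2 (1.17 log units; beyond the scatter). Nothing available explains why the two groups match or why both differ from compound 1.

As far as these compounds go, it remains open whether other groups on this carbon, such as a carboxylic acid, a methoxy group or a longer amine chain, would also stay within the scatter of compound 2 and compound 3. The compounds shown also do not separate the contribution of the chloro group of compound 1 from that of its trifluoromethyl group.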